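The source may report more compounds than this note shows. Statements on the series, on what has been measured and on what is new or still open speak of the compounds shown alone.

Measured so far:
- compound 1 `Cc1cn([C@@H]2O[C@H](CO)[C@@]3(OS(=O)(=O)C=C3NC(=O)NC(=O)c3ccccc3)[C@H]2O)c(=O)n(C)c1=O`: > 50000 nM in an ADME assay on HEL cells (Homo sapiens) for cytotoxicity, with a stated time of 3 days; a lower number here means that less compound is tolerated, a higher number that more compound is tolerated
- compound 2 `Cc1cn([C@@H]2O[C@H](CO[Si](C)(C)C(C)(C)C)[C@@]3(OS(=O)(=O)C=C3NC(=O)NC(=O)c3ccccc3)[C@H]2O)c(=O)n(C)c1=O`: 22000 nM in this assay

For compound 1 the value of > 50000 nM in this assay is a limit of the assay, not a number. Within the data shown here, compound 2 gives 22000 nM in this assay, and this is the only number in the set. The other value, that of compound 1, is a limit (the limit of > 50000 nM in this assay, at which 1 of the 2 values shown sits). Among the measured compounds shown here, the one measured step, an at least 2.2-fold lower number from compound 1 to compound 2 (0.35 log units; beyond the scatter), puts a group of 7 heavy atoms (6 carbon, 1 silicon; no ring) on the oxygen on a saturated carbon in place of a hydrogen atom.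

Compound 3 `Cc1cn([C@@H]2O[C@H](COC(=O)c3ccccc3)[C@@]3(OS(=O)(=O)C=C3NC(=O)NC(=O)c3ccccc3)[C@H]2O)c(=O)n(C)c1=O` differs from compound 2 at that same oxygen: a group of 8 heavy atoms (7 carbon, 1 oxygen; one six-membered aromatic ring of carbon only) in place of a group of 7 heavy atoms (6 carbon, 1 silicon; no ring), on an oxygen on a saturated carbon. For the measured compounds named here, no measured step covers an exchange of one substituent for another at this oxygen; the only step that bears on the site is an at least 2.2-fold lower number from compound 1 to compound 2 (0.35 log units; beyond the scatter), which concerns the presence of a substituent rather than its kind. Both substituents are of similar size, so no step beyond the scatter is expected from compound 2 to compound 3 in this assay. Compound 3 is estimated at 30000 nM, with a range from 10000 nM to 100000 nM, an expected step of a 1.4-fold higher number from compound 2 to compound 3 (0.13 log units; within the scatter).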

Compound 3, half-maximal cytotoxic concentration: > 100000 nM
Compound 3 ended at the assay's limit; the forecaster's own chance of this, stated with the estimate: 35%; at least 3.3-fold (0.52 log units) between middle value and limit.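

Working notes on the oxygen on a saturated carbon: the kind of substituent counts here, not only its presence, since benzoyl in place of the group of 6 carbon and 1 silicon gives an at least 4.5-fold higher number from compound 2 to compound 3 (0.65 log units; beyond the scatter) in this assay. The earlier step, an at least 2.2-fold lower number from compound 1 to compound 2 (0.35 log units; beyond the scatter), could be read as a cost of any substituent on this oxygen, but compound 3 carries a substituent of similar size and does not follow that reading, so the lower number belongs to compound 2 alone among the substituted compounds shown. Compound 3 gives a limit of the assay and not a number, and the step from compound 1 to compound 3 cannot be read: the limit of > 100000 nM in this assay, at which 1 of the 3 values shown sits.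

On these data alone, it remains open whether the carbonyl or the aromatic ring of benzoyl goes with the higher number, and an acetyl group or a benzyl group on this oxygen would separate the two. Also open, as far as these compounds go, are how the trimethylsilyl and triisopropylsilyl groups compare with the group in compound 2, and whether an amine or a carboxylic acid on a longer chain at this oxygen keeps the number at the limit.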